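Cyano in place of methyl: notes toward compound 4

A few compounds are considered here, and "the series" means these few. Any claim that something is new, unique, unknown or untested is made for them only; others in the source may bear on it.

Compound 2 `Cc1ccc2oc(C(=O)Nc3nnn[nH]3)cc(=O)c2c1` gives 0.075 ug/mL in a functional assay on cells (Mast cell, Rattus norvegicus) for inhibition, with a stated time of 15 min (on this read-out lower numbers stand for an effect already at smaller amounts and higher numbers for an effect only at larger amounts of compound), the lowest of the two numbers in hand; the nearest number, that of compound 3, lies beyond the scatter above it. Compound 3 `O=C(Nc1nc[nH]n1)c1cc(=O)c2ccccc2o1` gives 5 ug/mL in this assay. For compound 1 `O=C(Nc1nccs1)c1cc(=O)c2ccccc2o1` this assay reports only a limit, > 18 ug/mL. Among the measured compounds shown here, the one measured step, an at least 3.6-fold lower number from compound 1 to compound 3 (0.55 log units; beyond the scatter), concerns the group on the amide-type nitrogen, not the fused benzene ring.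

Compound 4 `N#Cc1ccc2oc(C(=O)Nc3nnn[nH]3)cc(=O)c2c1` differs from compound 2 by cyano in place of methyl on an aromatic carbon. For the measured compounds named here, no measured step touches this aromatic carbon, so nothing beyond the scatter is expected from the change. For compound 4 the expected value is 0.1 ug/mL (range 0.03 ug/mL to 0.4 ug/mL). This amounts to an expected step of a 1.3-fold higher number from compound 2 to compound 4 (0.12 log units; within the scatter).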

Compound 4, concentration for half-maximal effect: 2.3 ug/mL
Beside the measured number, compound 4's estimate is 23-fold (1.36 log units) below it; measured number above the stated range.
By their numbers in this assay, from the lowest: compound 2; then compound 4; then compound 3. At a limit, above all of these: compound 1.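

The aromatic carbon carrying methyl in compound 2 responds strongly in this assay: cyano in place of methyl gives a 31-fold higher number from compound 2 to compound 4 (1.49 log units; beyond the scatter). Among the compounds shown here, until now, the only measured step concerned the group on the amide-type nitrogen, so this is the first evidence that a substituent on this aromatic carbon can shift the read-out beyond the scatter. Nothing in hand accounts for the size of this step.

Open, as far as these compounds go, is how hydrogen, chlorine or a methoxy group would read at this aromatic carbon. Also open, from the compounds shown here alone, is whether the step from methyl to cyano carries over with 1H-1,2,4-triazol-3-yl on the amide-type nitrogen.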